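A few compounds are considered here, and "the series" means these few. Any claim that something is new, unique, unknown or untested is made for them only; others in the source may bear on it.

Measured compounds:
compound 1 `O=S(=O)(Nc1ccc(-c2nc3ccccc3o2)cc1)c1ccc(Cl)c(C(F)(F)F)c1`: 69000 nM
compound 2 `O=S(=O)(Nc1ccc2oc(-c3ccccc3)nc2c1)c1ccccc1Cl`: 73000 nM

Of the compounds shown here, two have been measured in an ADME assay on HEK293 cells (Homo sapiens) for cytotoxicity, read by resazurin assay, with a stated time of 48 h; on this read-out lower numbers stand for higher toxicity in this test and higher numbers for lower toxicity in this test. Compound 1 gives 69000 nM in this assay, and compound 2 gives 73000 nM in this assay. Compound 2 holds the higher of the two numbers, but its nearest neighbour, compound 1, sits within the scatter of it, so the two values show no ordering and no change between them; both simply point to low toxicity in this test.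

The next compound, compound 3 `O=S(=O)(Nc1ccc2oc(-c3ccccc3)nc2c1)c1ccc(Cl)s1`, has not yet been measured in this assay. It differs from compound 2 in one place: 5-chlorothiophen-2-yl in place of 2-chlorophenyl on a sulfonyl sulfur. The change is confined to the ring attached to the sulfonyl sulfur, while the rest of compound 2 is kept.

Within the data shown here, no measured step is available to guide this change. With both measured values lying close together, compound 3 is expected to stay in the same region, and the step of a 1.0-fold lower number from compound 2 to compound 3 (0.02 log units; within the scatter) is expected to be no larger than the scatter, in no fixed direction. Compound 3 is therefore estimated at 70000 nM in this assay, with a range from 35000 nM to 140000 nM.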

Compound 3, half-maximal cytotoxic concentration: > 100000 nM
Compound 3: no number, only a limit (the forecaster's own chance of this, stated with the estimate: 20%); middle value at least 1.4-fold (0.15 log units) from the limit.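

In this assay compound 3 gives > 100000 nM, which is a limit of the assay and not a number. Among these compounds, this is the first change that can be read at one place, the ring on the sulfonyl sulfur, and 5-chlorothiophen-2-yl in place of 2-chlorophenyl gives an at least 1.3-fold higher number from compound 2 to compound 3 (0.13 log units; that floor lies within the scatter), so the swap shows no sign of higher toxicity in this test, while its floor alone does not establish a real rise. On these data alone, only that floor can be stated for this step, and its full size stays unknown, because the value of compound 3 is a limit: the limit of > 100000 nM in this assay, at which 1 of the 3 values shown sits.

The compounds shown leave open whether the chlorine on the 5-chlorothiophen-2-yl ring plays any part in this result, and how the read-out would respond if an amine or a carboxylic acid stood on that ring in its place. Among the compounds shown here, they also leave open how far this change carries to other compounds, since compound 1 differs from compound 2 in more than one place and offers no second step of this kind.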